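The source may report more compounds than this note shows. Statements on the series, on what has been measured and on what is new or still open speak of the compounds shown alone.

Measured compounds:
Compound 1, `COc1cc(C(=O)c2cn(-c3ccccc3Cl)cc2-c2ccccc2)cc(OC)c1OC`: 1800 nM
Compound 2, `COc1cc(C(=O)c2cn(-c3ccccc3)cc2-c2ccccc2[N+](=O)[O-])cc(OC)c1OC`: 49 nM

Both were tested in a functional assay on MCF7 cells (Homo sapiens) for cytotoxicity, read by MTT assay, with a stated time of 96 h; a lower number here means a stronger inhibitor, a higher number a weaker inhibitor. Of the two numbers, compound 2 stands lowest; the nearest number is that of compound 1, and the gap between them lies beyond the scatter.

Compound 3, `COc1cc(C(=O)c2cn(-c3ccccc3)cc2/C=C/c2ccccc2)cc(OC)c1OC`, has not yet been measured in this assay. It differs from compound 2 in one place: 2-phenylethenyl in place of 2-nitrophenyl on an aromatic carbon. Among the compounds with values here, no step between measured compounds that differ in one place is available, so the effect of this change can only be estimated. The account expects a step of moderate size toward a higher number in this assay, since compound 2 gives 49 nM while compound 1 gives 1800 nM. Compound 3 is therefore estimated at 500 nM, within a range of 100 nM to 3000 nM. The estimate means an expected step of a 10-fold higher number from compound 2 to compound 3 (1.01 log units; beyond the scatter), beyond the scatter.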

Compound 3, half-maximal inhibitory concentration: 2200 nM
For compound 3 the middle estimate is 4.4-fold (0.64 log units) below the measured one; low and high end bracket the measured number.
By their numbers in this assay, from the lowest: compound 2; then compounds 1 and 3 (each within the scatter of the next).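

In this assay, the change on this aromatic carbon of the five-membered ring gives a 45-fold higher number from compound 2 to compound 3 (1.65 log units; beyond the scatter), the first step read at this position, and it shows that the number here depends strongly on the group the position bears. The step is large even though 2-nitrophenyl and 2-phenylethenyl each carry one six-membered aromatic ring of carbon only and one double bond outside aromatic rings; of the two, only 2-nitrophenyl holds nitrogen, oxygen and hydrogen-bond acceptors. Nothing measured here accounts for the step.

With one step, the compounds shown leave open whether the change follows the loss of the nitro group or the arrival of the ethenyl link. They also leave open how this position would respond to an amine or a methoxy group on the same phenyl ring.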